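The source may hold more compounds than are shown below. What is called first, only, known or untested is meant among the compounds shown, and "the series" means these compounds.

Measured so far:
- compound 3 `CCC(c1ccc(-c2ccsc2)cc1)n1ccnc1`; in an assay for inhibition of steroid 17-alpha-hydroxylase/17,20 lyase (Homo sapiens), using NADPH, tested at 2 uM (on this read-out higher numbers stand for a stronger effect at the one concentration tested and lower numbers for a weaker effect), compound 3 gives 83%
- compound 1 `CCC(c1ccc(-c2cscc2C)cc1)n1ccnc1`; compound 1 gives 84%
- compound 2 `c1cn(Cc2ccc(-c3ccoc3)cc2)cn1`; compound 2 gives 29%

Compound 3 holds the second highest of the three numbers. Its nearest neighbour is compound 1, which differs in one place, hydrogen in place of methyl on an aromatic carbon, and the step is a number 1 percentage points lower from compound 1 to compound 3 (within the scatter), so the two read-outs cannot be ordered. The furthest is compound 2, which differs in several places at once, and whose value of 29% lies well beyond the scatter below the numbers of compound 1 and compound 3.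

Compound 4 `CCC(c1ccc(-c2ccsc2Cl)cc1)n1ccnc1` is the next step from compound 3, with the change (chloro in place of hydrogen on an aromatic carbon). Going by the values given here, the one single-place step in hand, a number 1 percentage points lower from compound 1 to compound 3 (within the scatter), shows that adding or removing a small group on the same five-membered aromatic ring with one sulfur left the read-out within the scatter. Among the compounds with values here, no measured step involves chloro, and no step addresses the position next to the ring sulfur, so the bearing is indirect. On this basis the expected step is a number 3 percentage points lower from compound 3 to compound 4 (within the scatter), that is, no change beyond the scatter. The estimate for compound 4 in this assay is 80%, within a range of 62% to 92%.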

Compound 4, a percentage reported as inhibition, at one concentration (the size of the read-out at that concentration, not a potency): 85%
For compound 4 the middle estimate is 5 percentage points below the measured one; the range from low to high includes it.
By their numbers in this assay, from the lowest: compound 2; then compounds 3, 1 and 4 (each within the scatter of the next).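

In this assay, chloro in place of hydrogen on an aromatic carbon of the five-membered aromatic ring with one sulfur, next to the ring sulfur and next to the ring atom that bears a large group, gives a number 2 percentage points higher from compound 3 to compound 4 (within the scatter), so this position accepts chloro without a change beyond the scatter. Exchanging 4-methylthiophen-3-yl for 2-chlorothiophen-3-yl reads the same way, a number 1 percentage points higher from compound 1 to compound 4 (within the scatter), which means that compound 1, compound 3 and compound 4 cannot be ordered in this read-out and that a methyl group and a chloro group on this ring have so far given indistinguishable numbers. No supporting data are at hand to account for this result.

Going by these compounds alone, still open is whether an amine, a carboxylic acid or a longer chain at this position would also stay within the scatter of compound 3, or whether the position accepts only a single small atom or group such as chloro. Also open, on these data alone, is whether these three compounds would give a stronger or weaker effect than one another at other concentrations, since the read-out shows only the size of the effect at the one concentration tested, and how the much lower number of compound 2 divides among its several differences.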